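Swapping a halogenated benzoic acid on a shared core

This account rests on a few compounds, and the source may have more. Where it says the series, first, only, none or still open, it means among the compounds named here.

Compound 1, `CC#CCn1c(N2CCC[C@@H](N)C2)cc(=O)n(Cc2cccc(C(=O)O)c2Br)c1=O`, carries a 2-bromo-3-carboxyphenyl group on a saturated chain carbon bound to an aromatic nitrogen of the shared core. In an assay on isolated protein for inhibition of Dipeptidyl peptidase 9 (Homo sapiens), read by fluorescence, with stated times of 15 min and 20 min (on this read-out higher numbers stand for weaker inhibition and lower numbers for stronger inhibition), compound 1 gives "not determined" (no result reported), so no number exists for it. A close relative, compound 2, `CC#CCn1c(N2CCC[C@@H](N)C2)cc(=O)n(Cc2cc(C(=O)OC)ccc2Br)c1=O`, has been measured. In this assay compound 2 gives > 100 nM, which is a limit of the assay rather than a number, as the limit of > 100 nM in this assay, at which 1 of the 2 values shown sits, records. Compound 3, `CC#CCn1c(N2CCC[C@@H](N)C2)cc(=O)n(Cc2ccc(Cl)c(C(=O)O)c2)c1=O`, is not yet measured; it differs from compound 1 by 3-carboxy-4-chlorophenyl in place of 2-bromo-3-carboxyphenyl on a saturated chain carbon bound to an aromatic nitrogen. With no number for compound 1 and only a limit for compound 2, the size and direction of the step to compound 3 cannot be read from the shown results. On this basis compound 3 is expected to show weak inhibition in this assay, estimated at 3000 nM with a range of 300 nM to 30000 nM.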

Compound 3, half-maximal inhibitory concentration: > 100 nM
Compound 3: a limit, no number; the forecaster's own chance of this, stated with the estimate: 60%; the middle value does not contradict the limit.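

Compound 3 ends at a limit of the assay rather than a number, as compound 2 does: the limit of > 100 nM in this assay, at which 2 of the 3 values shown sit. Among the compounds shown here, with no number for compound 1 either, no step between compound 1 and compound 3 can be read. Going by these compounds, the actual strength of inhibition for all three compounds, and any effect of swapping 2-bromo-3-carboxyphenyl for 3-carboxy-4-chlorophenyl, stays open.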